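Oral exposure notes: aryl swap at the double-bonded ring carbon

The source may hold more compounds than are shown below. What is called first, only, known or untested is meant among the compounds shown, and "the series" means these compounds.

The series shares one core carrying different aryl groups. For the measured compounds named here, compound 2 `CC1=C(c2ccc(C#N)cc2)C(c2ccc(OC[C@H](C)N3CC[C@@H](C)C3)cc2)Oc2ccc(O)cc21` is the only member with a number in an ADME assay on the whole organism for pharmacokinetics, with Mus musculus as the target, at a dose of 10 mg/kg by the oral route; a higher number here means more compound in the circulation at the dose given, a lower number less compound in the circulation: compound 2 gives 2000 ng.h/mL. Compound 1 `CC1=C(c2ccc(S(C)(=O)=O)cc2)C(c2ccc(OC[C@H](C)N3CC[C@@H](C)C3)cc2)Oc2ccc(O)cc21` stands at "not determined" (no result reported) in this assay, and compound 3 `CC1=C(c2cccc(C#N)c2)C(c2ccc(OC[C@H](C)N3CC[C@@H](C)C3)cc2)Oc2ccc(O)cc21` likewise gives "not determined" (no result reported), so its position relative to compound 2 cannot be read from the data. Compound 4 `CC1=C(c2ccc(O)cc2)C(c2ccc(OC[C@H](C)N3CC[C@@H](C)C3)cc2)Oc2ccc(O)cc21` differs from compound 3 by 4-hydroxyphenyl in place of 3-cyanophenyl on a double-bonded ring carbon. Going by the values given here, no step between measured compounds exists for this change, so the size of its effect in this assay is open; a step downward beyond the scatter is expected rather than none. Compound 4 is estimated at 800 ng.h/mL, with a range from 200 ng.h/mL to 3000 ng.h/mL.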

Compound 4, area under the concentration-time curve: 460 ng.h/mL
Estimate against measurement, compound 4: 1.7-fold (0.24 log units) above; the range from low to high includes it.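

For the compounds shown here, the first readable change at this position in this assay is hydroxy in place of cyano on the aromatic ring, with a 4.3-fold lower number from compound 2 to compound 4 (0.64 log units; beyond the scatter) and so the group carried here does bear on the read-out. Steps to compound 1 and compound 3 cannot be read, as neither has a number. Nothing available accounts for the step.

Open, from the compounds shown here alone, is whether the 3-cyanophenyl of compound 3 stays with compound 2 or compound 4. Also open, going by these compounds, is where an amine or a carboxylic acid in place of the hydroxy would fall.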